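A few compounds are considered here, and "the series" means these few. Any claim that something is new, unique, unknown or untested is made for them only; others in the source may bear on it.

Of the compounds shown here, three have been measured in an assay on Ltk cells with metabotropic glutamate receptor 5 (Homo sapiens) as the target, read by fluorescence and calcium flux; on this read-out lower numbers stand for stronger inhibition and higher numbers for weaker inhibition. Compound 1 `CCOc1cccnc1Nc1cccc(C(F)(F)F)n1` gives 1900 nM. Compound 2 `CCOc1nccnc1Nc1cccc(C)n1` gives 497 nM. Compound 3 `CCOc1cc(-c2cccc(F)c2)cnc1Nc1cccc(C)n1` gives 126 nM, the lowest of the three numbers; its gap to compound 2 is beyond the scatter, and its gap to compound 1 is wider still. No pair among these three differs in a single place, so no step between measured compounds can be isolated.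

Compound 4 `CCOc1cc(-c2cnccc2C)cnc1Nc1cccc(C)n1` is not yet measured. It differs from compound 3 in one place: 4-methylpyridin-3-yl in place of 3-fluorophenyl on an aromatic carbon, placed on an aromatic carbon of a six-membered aromatic ring with one nitrogen, two atoms from the ring nitrogen, meta to an ethoxy group and para to a (6-methylpyridin-2-yl)amino group. Among the compounds with values here, nothing among the measured compounds shows how such an exchange of the pendant ring moves this assay, so the expectation rests on compound 3 alone. The step from compound 3 to compound 4 is expected to be a 1.4-fold higher number from compound 3 to compound 4 (0.15 log units; within the scatter), that is, no change beyond the scatter or a modest weakening. Compound 4 is therefore estimated at 180 nM, with a range from 60 nM to 600 nM.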

Compound 4, half-maximal inhibitory concentration: 45 nM
The estimate for compound 4 lay 4.0-fold (0.60 log units) above the measured number; measured number outside the range, below it.
By their numbers in this assay, from the lowest: compound 4; then compound 3; then compound 2; then compound 1.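

In this assay the position on the aromatic carbon para to the (6-methylpyridin-2-yl)amino group proves sensitive to the identity of the pendant ring: 4-methylpyridin-3-yl in place of 3-fluorophenyl gives a 2.8-fold lower number from compound 3 to compound 4 (0.45 log units; beyond the scatter) and so lies on the stronger side. Within the data shown here, this is the first change in one place that can be read, and it shows that a pendant ring with a ring nitrogen and a methyl group is accepted here with no loss. Nothing at hand accounts for the direction or size of this step.

The nitrogen and the methyl group enter together, so the compounds shown do not separate their shares in the step; a plain pyridin-3-yl or a methylphenyl ring would do so. They also leave open how a saturated amine such as morpholine would fare at this position.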